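Removing a Methyl from a Ring Amine Nitrogen

The source may report more compounds than this note shows. Statements on the series, on what has been measured and on what is new or still open speak of the compounds shown alone.

Of the compounds shown here, three have so far been measured in an in vitro assay on SH-EP1 cells for displacement of a labelled ligand from Neuronal acetylcholine receptor; alpha4/beta2 (Homo sapiens); a lower number here means a stronger inhibitor, a higher number a weaker inhibitor. Compound 1, `Clc1cccc(Oc2cncc(C3=CC4CNCC(C3)C4)c2)c1`, gives 1 nM. Compound 2, `C1=C(c2cccnc2)CC2CNCC1C2`, gives 0.2 nM. Compound 3, `COc1cncc(C2=CC3CC(C2)CN(C)C3)c1`, gives 0.6 nM. Among these three numbers, compound 3 holds the second highest. Its nearest neighbour is compound 1, whose number is somewhat higher, but the gap lies within the usual scatter, so the two cannot be told apart. Compound 2 sits furthest away, with a lower number that lies beyond the scatter.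

Compound 4, `COc1cncc(C2=CC3CNCC(C2)C3)c1`, has not yet been measured. It differs from compound 3 in a single place: hydrogen in place of methyl on an amine nitrogen in a ring.

Within the data shown here, no pair of measured compounds shows this exact change, so nothing measured fixes its size. Compound 1 and compound 2 both carry hydrogen on an amine nitrogen in a ring, and their numbers bracket that of compound 3, which points to no large shift. The step is expected to be small, a 1.7-fold lower number from compound 3 to compound 4 (0.23 log units; within the scatter), toward a lower number, and may well fall within the scatter. Compound 4 is therefore expected to give about 0.35 nM, with a likely range from 0.1 nM to 1.2 nM.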

Compound 4, inhibition constant: 0.3 nM
Compound 4: the middle estimate sits 1.2-fold (0.07 log units) above what was measured, and the stated range covers the measured number.
By their numbers in this assay, from the lowest: compounds 2, 4, 3 and 1 (each within the scatter of the next, the first and the last beyond it).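

Read directly for the first time in this assay, hydrogen in place of methyl on this amine nitrogen in a ring gives a 2.0-fold lower number from compound 3 to compound 4 (0.30 log units; within the scatter), so the methyl can be removed here without a shift that stands clear of repeat-measurement noise. With hydrogen on that nitrogen, methoxy in place of hydrogen on an aromatic carbon gives a 1.5-fold higher number from compound 2 to compound 4 (0.18 log units; within the scatter), so this addition also leaves the number indistinguishable. Methyl in place of 3-chlorophenyl on an oxygen on an aromatic ring gives a 3.3-fold lower number from compound 1 to compound 4 (0.52 log units; beyond the scatter), and this is the only one of the three steps that lies beyond the scatter, which makes the group on that oxygen the one place in this small set where a change can be told apart.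

From the compounds shown here alone, whether a larger group on the ring nitrogen, such as ethyl or benzyl, would be tolerated as well as methyl remains open, as does whether removing the methyl has a similar effect when 3-chlorophenyl sits on the oxygen. Nothing available here explains the size of any of these steps.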